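This account rests on a few compounds, and the source may have more. Where it says the series, first, only, none or still open, it means among the compounds named here.

In a functional assay on HUVEC cells (Homo sapiens) for inhibition (a higher number here means a weaker inhibitor, a lower number a stronger inhibitor), compound 3 `COc1ccc2[nH]c(C(N)=O)c(OC(C)C)c2c1` gives 7900 nM, within the scatter of compound 2 `COc1ccc2c(c1)c(OC(C)C)c(C(N)=O)[s+]2[O-]`, which gives 6600 nM. Compound 1 `COc1cccc2c(OC(C)C)c(C(N)=O)sc12` is reported only as a limit, < 4000 nM. Compound 4 `COc1ccc2c(c1)c(OC(C)C)c(C(N)=O)n2C` differs from compound 3 by methyl in place of hydrogen on an aromatic nitrogen. Among the measured compounds shown here, no measured pair of compounds tests this change, and no shift beyond the scatter is expected in this assay, in either direction. That expectation is anchored only on compound 3, at 7900 nM. The expected change is a 1.0-fold higher number from compound 3 to compound 4 (0.01 log units; within the scatter). Compound 4 is estimated at 8000 nM, with an expected range from 3000 nM to 20000 nM.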

Compound 4, half-maximal inhibitory concentration: 9200 nM
For compound 4 the middle estimate is 1.2-fold (0.06 log units) below the measured one, within the range that was stated.
By their numbers in this assay, from the lowest: compounds 2, 3 and 4 (each within the scatter of the next). At a limit, below all of these: compound 1.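

Methyl on the aromatic nitrogen, in place of the hydrogen of compound 3, was tolerated in this assay, giving a 1.2-fold higher number from compound 3 to compound 4 (0.07 log units; within the scatter). Among the compounds shown here, this is the only measured pair that tests the position, and it shows that the nitrogen can carry methyl without a shift beyond the scatter. Nothing measured here accounts for the size of this step.

The compounds shown hold only hydrogen and methyl on this nitrogen. On these data alone, whether a longer chain such as ethyl, or a chain ending in an amine or a carboxylic acid, would move the number remains open.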